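Swapping the chlorophenyl arm of a pyrazole channel blocker

A few compounds are considered here, and "the series" means these few. Any claim that something is new, unique, unknown or untested is made for them only; others in the source may bear on it.

Compound 1 `COc1ccccc1-n1nc(C2CC(C)(C)OC(C)(C)C2)cc1-c1ccc(Cl)cc1`: 1 nM
Compound 2 `COc1ccccc1-n1nc(C2CCOC(C)(C)C2)cc1-c1ccc(Cl)cc1`: 2 nM
Compound 3 `COc1ccccc1-n1nc(C2C[C@H](C)O[C@@H](C)C2)cc1-c1ccc(Cl)cc1`: 2 nM

Three compounds share one core and differ only in the oxane group on the five-membered ring. In an assay on HEK293 cells for inhibition of Voltage-dependent N-type calcium channel subunit alpha-1B (Homo sapiens), read by fluorescence and calcium flux, with a stated time of 5 min (a higher number here means a weaker inhibitor, a lower number a stronger inhibitor), compound 1 gives 1 nM, the lowest number of the three, yet the gap to each neighbour is small: a 2.0-fold higher number from compound 1 to compound 2 (0.30 log units; within the scatter), and a 2.0-fold higher number from compound 1 to compound 3 (0.30 log units; within the scatter). Between compound 2 and compound 3 the picture is the same, no change at the digits printed from compound 2 to compound 3 (within the scatter). These steps therefore say nothing about the chlorophenyl arm, which is where compound 4 `CCOc1ccc(-c2cc(C3CC(C)(C)OC(C)(C)C3)nn2-c2ccccc2OC)cn1` departs from compound 1: 6-ethoxypyridin-3-yl in place of 4-chlorophenyl on an aromatic carbon.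

Going by the values given here, none of the measured steps touches this position, so the expectation for compound 4 rests on the value of compound 1 alone, with no measured step to indicate a direction. The oxane changes, all within scatter, suggest the core tolerates variation, but that is a different site. The estimate for compound 4 is therefore centred close to compound 1 with a wide range: in this assay compound 4 is expected to give 3 nM, between 0.7 nM and 15 nM, which means an expected step of a 3.0-fold higher number from compound 1 to compound 4 (0.48 log units; beyond the scatter).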

Compound 4, half-maximal inhibitory concentration: 5 nM
Beside the measured number, compound 4's estimate is 1.7-fold (0.22 log units) below it, and the stated range covers the measured number.
By their numbers in this assay, from the lowest: compounds 1, 2 and 3 (each within the scatter of the next); then compound 4.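

Going by these compounds alone, compound 4 gives the first measured step at this position, and in this assay the change from 4-chlorophenyl to 6-ethoxypyridin-3-yl amounts to a 5.0-fold higher number from compound 1 to compound 4 (0.70 log units; beyond the scatter). Unlike the oxane changes, all of which stayed within the scatter, this replacement of the arm on the five-membered ring moves the number beyond the scatter, although the step is modest. The position therefore responds to the change yet still accepts a larger group carrying a ring nitrogen and hydrogen-bond acceptors, with compound 4 at 5 nM in this assay, while nothing available here accounts for the size or direction of the step.

Because the ring and its substituent change together, the compounds shown do not separate the effect of the ring nitrogen from that of exchanging chlorine for ethoxy, a question that 4-ethoxyphenyl or 6-chloropyridin-3-yl at this position would address. They also leave open how a shorter methoxy group, a longer propoxy chain or an amine on the pyridine ring would read, and whether the oxane changes would remain as small alongside the 6-ethoxypyridin-3-yl arm.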